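The source may hold more compounds than are shown below. What is called first, only, known or untested is meant among the compounds shown, and "the series" means these compounds.

Three compounds built on one shared core had been examined in a functional assay on the whole organism for inhibition, with Rattus norvegicus as the target, read by paw edema, with stated times of 1 h and 3 h, at a dose of 100 mg/kg by the oral route; a lower number here means less inhibition, a higher number more inhibition at the dose given (going by the name of the read-out). Compound 1 `O=C(O)c1ccc(NC(=O)[C@@H]2CC(O)CN2S(=O)(=O)c2ccc([N+](=O)[O-])cc2)cc1` gave 62.8%, compound 2 `Cc1ccc(S(=O)(=O)N2CC(O)C[C@H]2C(=O)Nc2ccc(C(=O)O)cc2)cc1` gave 84%, and compound 3 `O=C(O)c1ccc(NC(=O)[C@@H]2CC(O)CN2S(=O)(=O)c2ccccc2)cc1` gave 1.85%. Compound 2 stood highest of the three, with a number 21.2 percentage points higher from compound 1 to compound 2 (beyond the scatter) and a number 82.2 percentage points lower from compound 2 to compound 3 (beyond the scatter); the remaining pair showed a number 61 percentage points lower from compound 1 to compound 3 (beyond the scatter). Compound 4 `Cc1ccc(S(=O)(=O)N2CCC[C@H]2C(=O)Nc2ccc(C(=O)O)cc2)cc1` differed from compound 2 in one respect: hydrogen in place of hydroxy on a saturated ring carbon. All three measured steps changed the group on the aromatic carbon, so none of them bore on removing a hydroxy from the saturated ring, and no direction could be predicted in this assay beyond the scatter. The number for compound 4 was therefore estimated at 70%, within 35% to 95%, which meant an expected step of a number 14 percentage points lower from compound 2 to compound 4 (beyond the scatter).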

Compound 4, a percentage reported as inhibition, in the whole organism at one dose (the size of the read-out at that dose, not a potency): 35.3%
For compound 4 the middle estimate is 34.7 percentage points above the measured one, and the stated range covers the measured number.
By their numbers in this assay, from the lowest: compound 3; then compound 4; then compound 1; then compound 2.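

Removing the hydroxy gave a number 48.7 percentage points lower from compound 2 to compound 4 (beyond the scatter) in this assay. Within the data shown here, the earlier steps all lay on the aromatic carbon, so this is the first sign that the saturated ring carbon also matters to the response, though only with methyl on the aromatic carbon. No evidence is available to account for this step. Going by these compounds, it remains open whether the hydroxy counts as much with nitro or hydrogen on the aromatic carbon, and how an amine or a methoxy group on the saturated ring carbon would compare.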